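Thiophen-2-yl in Place of 3-Cyanophenyl at the Cyclopropane

This account rests on a few compounds, and the source may have more. Where it says the series, first, only, none or still open, it means among the compounds named here.

compound 1 `CC(C)C[C@H](N)CN(C(=O)[C@@H]1C[C@H]1c1ccccc1)c1ccc(-c2ccccc2)cc1`: 880 nM
compound 2 `CC[C@H](C)[C@H](N)CN(C(=O)[C@@H]1C[C@H]1c1cccc(C#N)c1)c1ccc(-c2ccccc2)cc1`: 1600 nM

Of the compounds shown here, two have been tested in a functional assay for agonist activity at G protein-coupled receptor 88 (Homo sapiens), read by HTRF and cAMP accumulation; on this read-out lower numbers stand for an effect already at smaller amounts and higher numbers for an effect only at larger amounts of compound. Compound 1 gives 880 nM, and compound 2 gives 1600 nM. Within the data shown here, compound 2 thus carries the higher of the two numbers, yet its only neighbour, compound 1, lies within the usual scatter, so the two results cannot be told apart. Among the measured compounds shown here, no pair of measured compounds differs in a single place, so no step size has been established.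

Compound 3 `CC[C@H](C)[C@H](N)CN(C(=O)[C@@H]1C[C@H]1c1cccs1)c1ccc(-c2ccccc2)cc1` is the next compound to be examined. It is derived from compound 2 by one change: thiophen-2-yl in place of 3-cyanophenyl on a saturated ring carbon. Since nothing measured speaks to this exchange, the step from compound 2 to compound 3 is expected to be modest, with no clear direction, and is estimated as a 1.3-fold lower number from compound 2 to compound 3 (0.12 log units; within the scatter). In this assay compound 3 is therefore expected to give about 1200 nM, most likely between 400 nM and 4000 nM.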

Compound 3, half-maximal effective concentration: 360 nM
Compound 3: the middle estimate sits 3.3-fold (0.52 log units) above what was measured; the measured number lies below the stated range.
By their numbers in this assay, from the lowest: compound 3; then compounds 1 and 2 (each within the scatter of the next).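

In this assay, among these compounds, thiophen-2-yl in place of 3-cyanophenyl on the saturated ring carbon gives a 4.4-fold lower number from compound 2 to compound 3 (0.65 log units; beyond the scatter), the first single-place step. This shows that the aromatic group at this position of the cyclopropane can move the number beyond the scatter, which compounds 1 and 2 could not show, since they differ in more than one place. No measurement bearing on the reason for this step is available.

The single exchange removes the nitrile and changes the ring at once, so the compounds shown do not say which of these changes accounts for the step. Also open, from the compounds shown here alone, is how furan-2-yl or thiophen-3-yl would behave at this position, and whether the step would hold with the side chain of compound 1.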